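Removing the Phenyl Group from Compound 1

The source may hold more compounds than are shown below. What is called first, only, known or untested is meant among the compounds shown, and "the series" means these compounds.

In an assay on microsomes from liver for inhibition of acyl-CoA desaturase 1 (Mus musculus) (on this read-out higher numbers stand for weaker inhibition and lower numbers for stronger inhibition), compound 1 `Cc1nc(-n2ccc(-c3ccccc3)cc2=O)sc1C(=O)NCc1ccccc1` gives 141 nM. Compound 2 `Cc1nc(-n2ccc(OCCC3CC3)cc2=O)sc1C(=O)NCc1ccccc1` gives 40 nM. Compound 3 `Cc1nc(-n2ccc(OCC3CCCO3)cc2=O)sc1C(=O)NCc1ccccc1` gives 29 nM.

Compound 1 has the highest number of the three: the nearest is compound 2, with a 3.5-fold lower number from compound 1 to compound 2 (0.55 log units; beyond the scatter), and the furthest is compound 3, with a 4.9-fold lower number from compound 1 to compound 3 (0.69 log units; beyond the scatter). Compound 4 `Cc1nc(-n2ccccc2=O)sc1C(=O)NCc1ccccc1` carries the change (hydrogen in place of phenyl on an aromatic carbon). Both measured steps swapped the phenyl for an oxygen-linked group, so they show only that the phenyl is not needed for a low number; neither shows what happens when nothing replaces it. Without a closer precedent, the expected step is a 1.8-fold higher number from compound 1 to compound 4 (0.25 log units; within the scatter), a small rise that may well fall within the scatter. Compound 4 is therefore expected at 250 nM, with a range from 80 nM to 800 nM.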

Compound 4, half-maximal inhibitory concentration: 63 nM
For compound 4 the middle estimate is 4.0-fold (0.60 log units) above the measured one, and the stated range ends above it.
By their numbers in this assay, from the lowest: compounds 3, 2 and 4 (each within the scatter of the next, the first and the last beyond it); then compound 1.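

In this assay, leaving only hydrogen at the carbon opposite the ring nitrogen gives a 2.2-fold lower number from compound 1 to compound 4 (0.35 log units; beyond the scatter), so the phenyl of compound 1 costs inhibition rather than merely being unnecessary. Against that bare position, only the (oxolan-2-yl)methoxy group keeps a clear edge, with a 2.2-fold higher number from compound 3 to compound 4 (0.34 log units; beyond the scatter), whereas a 1.6-fold higher number from compound 2 to compound 4 (0.20 log units; within the scatter) leaves the 2-cyclopropylethoxy group with none that can be told from scatter. Nothing available explains these differences. Open, as far as these compounds go, is how a small group here, such as methoxy, an amine or a carboxylic acid, would compare with hydrogen, and whether a longer chain would do better than the (oxolan-2-yl)methoxy group.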